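Swapping Nitro for Chloro on a Benzamide Sulfonamide

The source may hold more compounds than are shown below. What is called first, only, known or untested is meant among the compounds shown, and "the series" means these compounds.

Compound 1 `Cc1ccc(S(=O)(=O)NCc2ccc(CNC(=O)c3ccc([N+](=O)[O-])cc3)cc2)cc1` is tested in an assay on MDA-MB-231 cells for binding affinity to C-X-C chemokine receptor type 4 (Homo sapiens), read by immunofluorescence and microscopy, with stated times of 10 min and 30 min (a higher number here means that more compound is needed for the effect, a lower number that less compound is needed), where compound 1 gives 10 nM. Compound 2 `O=C(NCc1ccc(CNS(=O)(=O)c2ccccc2)cc1)c1cccnc1` gives 10 nM, so compound 1 and compound 2 stand level within the scatter and together sit highest of the three. For the measured compounds named here, compound 3 `COc1ccccc1C(=O)NCc1ccc(CNS(=O)(=O)c2ccccc2)cc1` gives 1 nM; the only measured step, a 10-fold lower number from compound 2 to compound 3 (1.00 log units; beyond the scatter), changes the group on the carbonyl carbon. Compound 4 `Cc1ccc(S(=O)(=O)NCc2ccc(CNC(=O)c3ccc(Cl)cc3)cc2)cc1` differs from compound 1 by chloro in place of nitro on an aromatic carbon. Going by the values given here, no measured step alters this same group, and the step from compound 2 to compound 3 concerns another part of the molecule, so it offers only an indirect hint that changes on this ring can move the number modestly. Compound 4 is therefore expected to show a step of only no change at the digits printed from compound 1 to compound 4 (within the scatter). The estimate for compound 4 is 10 nM, in a range from 3 nM to 30 nM.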

Compound 4, effective concentration (reported as EC, without a stated level of effect): 10 nM
Compound 4: middle estimate and measured number agree at the digits printed, within the range that was stated.
By their numbers in this assay, from the lowest: compound 3; then compounds 1, 2 and 4 (each within the scatter of the next).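

In this assay, for the compounds shown here, chloro in place of nitro gives no change at the digits printed from compound 1 to compound 4 (within the scatter), the first direct reading at this place on the ring. A group of three heavy atoms with two hydrogen-bond acceptors can therefore be replaced here by a single chlorine with none, without a shift beyond the scatter. Nothing measured here explains why the two compounds read alike. As far as these compounds go, whether an amine or a carboxylic acid in place of nitro would also leave the number level stays open. So does whether chloro would read the same elsewhere on this ring.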